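Notes on the step from compound 3 to compound 4

The source may report more compounds than this note shows. Statements on the series, on what has been measured and on what is new or still open speak of the compounds shown alone.

Read-outs in an ADME assay on HEK293 cells (Homo sapiens) for cytotoxicity, read by resazurin assay, with a stated time of 72 h; a higher number here means that more compound is tolerated, a lower number that less compound is tolerated:
- compound 1 `COc1cccc(CNC(=O)c2nc3ccc(F)c(OCCc4ccc(N)cc4)c3c(=O)[nH]2)c1`: > 20000 nM
- compound 2 `CCc1cccc(CNC(=O)c2nc3ccc(F)c(COc4ccc(C(=O)O)cc4)c3c(=O)[nH]2)c1`: > 20000 nM
- compound 3 `CCc1cccc(CNC(=O)c2nc3cccc(COc4ccc(C(=O)O)cc4)c3c(=O)[nH]2)c1`: > 20000 nM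

Each of these entries is a limit of the assay and not a number. Compound 3 therefore has only a limit, shared by the whole series: the limit of > 20000 nM in this assay, at which 3 of the 3 values shown sit.

Compound 4 `CCc1cccc(CNC(=O)c2nc3cccc(CSCc4ccc(C(=O)O)cc4)c3c(=O)[nH]2)c1` carries (4-carboxybenzyl)sulfanyl in place of 4-carboxyphenoxy on a saturated chain carbon bound to an aromatic carbon.

Within the data shown here, the single measured step, a step that the two limits leave unreadable from compound 2 to compound 3, has no readable size and offers no magnitude to carry over. No step beyond the scatter is expected in this assay, and a further limit is the likeliest report. For compound 4 the estimated value is 25000 nM, with an expected range of 12000 nM to 40000 nM. The estimate corresponds to an expected step that the limit leaves unreadable from compound 3 to compound 4.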

Compound 4, half-maximal cytotoxic concentration: > 20000 nM
Compound 4 gave a limit, no number; the forecaster's own chance of this, stated with the estimate: 85%; the middle value lies beyond the limit too.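

Compound 3 and compound 4 both gave a limit and not a number, so no step between them can be read: the limit of > 20000 nM in this assay, at which 4 of the 4 values shown sit.

The compounds shown leave open whether (4-carboxybenzyl)sulfanyl in place of 4-carboxyphenoxy makes any difference in this assay.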